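Solubility of Four Diaminoquinoline Analogues Compared

The compounds below may be only part of what the source reports. "The series", "measured", "known", "first", "only" and "open" are said of these compounds alone.

Compound 1 `CN(C)c1cccc(Oc2ccc3c(NCCCNCc4ccco4)ccnc3c2)c1` is the reference point of the series. In a physicochemical assay for solubility, with a stated time of 18 h, at pH 7.4 (on this read-out lower numbers stand for lower solubility and higher numbers for higher solubility), compound 1 gives 14500 nM. Compound 3 `COc1cccc(CNCCCNc2ccnc3cc(Oc4cccc(N(C)C)c4)ccc23)c1O` keeps everything else and carries 2-hydroxy-3-methoxyphenyl in place of furan-2-yl on a saturated chain carbon bound to an amine nitrogen. In this assay compound 3 gives 14500 nM, so that no change at the digits printed from compound 1 to compound 3 (within the scatter), a result that lies within the scatter of the measurement.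

Compound 2 `FC(F)(F)c1cc(-c2ccc3c(NCCCNCc4ccco4)ccnc3c2)cc(C(F)(F)F)c1` differs from compound 1 in its core; that difference between the two cores is not broken down here. In this assay compound 2 gives 32000 nM, the highest number among the three measured compounds, with compound 1 and compound 3 each standing a step below it that is beyond the scatter.

Compound 4 `COc1cccc(CNCCCNc2ccnc3cc(-c4cc(C(F)(F)F)cc(C(F)(F)F)c4)ccc23)c1O` has not yet been measured. It is built from compound 2 by the same change that turns compound 1 into compound 3: 2-hydroxy-3-methoxyphenyl in place of furan-2-yl on a saturated chain carbon bound to an amine nitrogen. Going by the values given here, since the only measured instance of this change, no change at the digits printed from compound 1 to compound 3 (within the scatter), produced no movement in solubility, the expectation for compound 4 is that the same change on the core of compound 2 will again leave the number where it stands, giving no change at the digits printed from compound 2 to compound 4 (within the scatter). On that basis compound 4 is estimated to show 32000 nM in this assay, with a plausible range from 14000 nM to 70000 nM, an estimate that rests on a single measured precedent and on the value of compound 2.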

Compound 4, solubility: 32000 nM
Compound 4: the middle estimate sits on the measured number at the digits printed; measured number inside the range.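

In this assay the replacement of furan-2-yl by 2-hydroxy-3-methoxyphenyl, on a saturated chain carbon bound to an amine nitrogen, now gives no change at the digits printed from compound 2 to compound 4 (within the scatter), which matches the earlier result of no change at the digits printed from compound 1 to compound 3 (within the scatter), so in both pairs the read-out stays where the parent compound put it. The two pairs keep their own levels, with compound 3 at 14500 nM and compound 4 at 32000 nM, so on these printed values the core of the compound, and not this replacement, goes with the difference seen in this small set. Going by these compounds alone, this is agreement across only two cores for a single replacement, so it does not establish a rule for the series, and nothing measured here explains why the number holds still in either pair.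

The compounds shown leave open whether the same flat result would appear on a third core, or with a carboxylic acid or a piperidine in place of the furan-2-yl group on that chain carbon. They also leave open what a longer chain carrying the amine nitrogen would do to the read-out on either core.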